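A Nitro Group Tested on Two Related Cores

This account rests on a few compounds, and the source may have more. Where it says the series, first, only, none or still open, it means among the compounds named here.

Compound 1 `O=C1OCC[C@@H]1NC(=S)SCCOc1ccc([N+](=O)[O-])cc1` and compound 2 `O=C1OCC[C@@H]1NC(=S)SCCOc1ccccc1` share one core, while compound 3 `O=C(COc1ccc(C(=O)/C=C/c2ccccc2)cc1)N[C@H]1CCOC1=O` is built on another; the difference between the two cores is not broken down here. In a functional assay on DU-145 cells (Homo sapiens) for antiproliferative activity, read by MTT assay, with a stated time of 72 h (a higher number here means a weaker inhibitor, a lower number a stronger inhibitor), compound 2 gives 63800 nM, compound 1 gives 31000 nM, and compound 3 gives 48300 nM. Among the measured compounds shown here, the single change that connects compound 2 with compound 1 is nitro in place of hydrogen on an aromatic carbon, and it produced a step of a 2.1-fold lower number from compound 2 to compound 1 (0.31 log units; beyond the scatter). Compound 4 `O=C(COc1ccc(C(=O)/C=C/c2cccc([N+](=O)[O-])c2)cc1)N[C@H]1CCOC1=O` has not yet been measured in this assay. It differs from compound 3 by nitro in place of hydrogen on an aromatic carbon. For the measured compounds named here, this is the same kind of change as the one from compound 2 to compound 1, though not the same change: in compound 1 the nitro sits para to a large group, whereas in compound 4 it sits meta to a large group. Because the step of a 2.1-fold lower number from compound 2 to compound 1 (0.31 log units; beyond the scatter) was modest, a step of similar size is expected on the second core, and for compound 4 the expected step is a 1.9-fold lower number from compound 3 to compound 4 (0.29 log units; within the scatter). Compound 4 is accordingly estimated at 25000 nM, within a range from 10000 nM to 60000 nM.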

Compound 4, half-maximal inhibitory concentration: 41800 nM
Beside the measured number, compound 4's estimate is 1.7-fold (0.22 log units) below it, and the stated range covers the measured number.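

In this assay, nitro in place of hydrogen on the core of compound 3 gives a 1.2-fold lower number from compound 3 to compound 4 (0.06 log units; within the scatter), a pair that this read-out cannot tell apart, while the same kind of change on the other core gave a 2.1-fold lower number from compound 2 to compound 1 (0.31 log units; beyond the scatter). The two steps do not differ by more than repeated measurements would allow: the same change on two cores in this assay, a 2.1-fold lower number (0.31 log units; beyond the scatter) from compound 2 to compound 1 and a 1.2-fold lower number (0.06 log units; within the scatter) from compound 3 to compound 4, 1.8-fold (0.25 log units) apart, within the scatter of two such steps. Among the compounds shown here, this shows no detectable disagreement between the cores, but it does not show that the change acts equally on both: only one of the steps lies beyond the scatter, each core offers a single pair, and the nitro does not stand in the same place in the two pairs.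

The compounds shown leave open whether an amine or a carboxylic acid on the same aromatic carbon would give steps that agree across the two cores. They also leave open whether a nitro at another place on the phenyl ring of the core of compound 3 would give a step beyond the scatter.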